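This account rests on a few compounds, and the source may have more. Where it says the series, first, only, none or still open, it means among the compounds named here.

Measured so far in an ADME assay on L1210/0 cells (Mus musculus) for cytotoxicity, with a stated time of 48 h; on this read-out lower numbers stand for stronger inhibition and higher numbers for weaker inhibition:

Compound 1 `O=C1O/C(=C\Cn2cc(F)c(=O)[nH]c2=O)C(OCc2ccccc2)=C1OCc1ccccc1` gives 5100 nM.
Compound 2 `O=C1O/C(=C\Cn2ccc(=O)[nH]c2=O)C(OCc2ccccc2)=C1OCc1ccccc1` gives 12900 nM.
Compound 3 `O=C1OC(C(O)Cn2cc(F)c(=O)[nH]c2=O)C(OCc2ccccc2)=C1OCc1ccccc1` gives 140000 nM.

Compound 1 and compound 2 share one core and differ in a single place: hydrogen in place of fluoro on an aromatic carbon. This change gives a 2.5-fold higher number from compound 1 to compound 2 (0.40 log units; beyond the scatter). Compound 3 differs from compound 1 in more than one place, and the difference between the two cores is not broken down here. In this assay compound 3 stands with the highest number of the three, beyond the usual scatter of both compound 1 and compound 2.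

Compound 4 `O=C1OC(C(O)Cn2ccc(=O)[nH]c2=O)C(OCc2ccccc2)=C1OCc1ccccc1` has not yet been measured. It stands to compound 3 as compound 2 stands to compound 1: hydrogen in place of fluoro on an aromatic carbon. The place is the same as in the earlier pair, so this is the same change, occurring twice among the compounds shown.

The expected step in this assay is a 2.5-fold higher number from compound 3 to compound 4 (0.40 log units; beyond the scatter). Within the data shown here, that expectation rests on the single measured example of this change, a 2.5-fold higher number from compound 1 to compound 2 (0.40 log units; beyond the scatter), taken as a guide. For compound 4 the estimated value in this assay is 350000 nM, expected to fall between 150000 nM and 800000 nM.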

Compound 4, half-maximal inhibitory concentration: 157000 nM
The estimate for compound 4 lay 2.2-fold (0.35 log units) above the measured number, within the range that was stated.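

In this assay, hydrogen in place of fluoro on the aromatic carbon of the core of compound 3 gives a 1.1-fold higher number from compound 3 to compound 4 (0.05 log units; within the scatter), so on this core the change leaves no readable difference. Set beside the earlier step on the core of compound 1, the two results do not separate: the same change on two cores in this assay, a 2.5-fold higher number (0.40 log units; beyond the scatter) from compound 1 to compound 2 and a 1.1-fold higher number (0.05 log units; within the scatter) from compound 3 to compound 4, 2.3-fold (0.35 log units) apart, within the scatter of two such steps. The change can therefore be carried between these two cores with no demonstrated difference in its size, but two pairs establish neither a constant step nor a step that depends on the core.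

The compounds shown carry only fluoro or hydrogen at this place, so chloro, methyl or trifluoromethyl there remains open. Equally open, from the compounds shown here alone, is whether the step holds when the benzyl groups give way to methyl groups or to a longer chain.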